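The source may hold more compounds than are shown below. What is called first, only, known or untested is meant among the compounds shown, and "the series" means these compounds.

Of the compounds shown here, three that share one core have been tested in a functional assay on SK-OV-3 cells (Homo sapiens) for antiproliferative activity, read by MTT assay, with a stated time of 72 h; a lower number here means a stronger inhibitor, a higher number a weaker inhibitor. Compound 1 `O=C(CCc1cccc2c1B(O)OC2)Nc1cccc(-c2ccc(F)cc2)c1` gives 93 nM. Compound 2 `O=C(CCc1cccc2c1B(O)OC2)Nc1cccc(-c2ccc(Cl)cc2)c1` gives 220 nM. Compound 3 `O=C(CCc1cccc2c1B(O)OC2)Nc1cccc(-c2ccc(OC(F)(F)F)cc2)c1` gives 560 nM. On these numbers compound 2 stands second highest of the three, with compound 1 as its nearest neighbour, lower, and compound 3 as its furthest, higher. The measured steps are a 2.4-fold higher number from compound 1 to compound 2 (0.37 log units; beyond the scatter), a 6.0-fold higher number from compound 1 to compound 3 (0.78 log units; beyond the scatter) and a 2.5-fold higher number from compound 2 to compound 3 (0.41 log units; beyond the scatter), each a modest weakening as the group on the outer ring is exchanged.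

Compound 4 `CC(=O)c1cccc(-c2cccc(NC(=O)CCc3cccc4c3B(O)OC4)c2)c1` has not yet been measured. It differs from compound 2 by 3-acetylphenyl in place of 4-chlorophenyl on an aromatic carbon. Among the compounds with values here, no measured step brings in an acetyl group, so the bearing of the earlier steps is only indirect: every exchange on the outer ring so far, from compound 1 to compound 2 and on to compound 3, has raised the number in this assay by a modest amount. A modest rise is therefore expected here as well, with wide uncertainty. Compound 4 is estimated at 400 nM, within a range from 130 nM to 1300 nM, which would mean an expected step of a 1.8-fold higher number from compound 2 to compound 4 (0.26 log units; within the scatter).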

Compound 4, half-maximal inhibitory concentration: 68 nM
Estimate against measurement, compound 4: 5.9-fold (0.77 log units) above, outside the stated range (below it).
By their numbers in this assay, from the lowest: compounds 4 and 1 (each within the scatter of the next); then compound 2; then compound 3.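

Up to this point, each exchange on the outer ring had only raised the number in this assay, but 3-acetylphenyl in place of 4-chlorophenyl gives a 3.2-fold lower number from compound 2 to compound 4 (0.51 log units; beyond the scatter), so a change at this position can also lower it. This larger group, which adds a hydrogen-bond acceptor, also gives a 1.4-fold lower number from compound 1 to compound 4 (0.14 log units; within the scatter), which leaves compound 4 and compound 1 indistinguishable in this test, so the best result so far does not depend on a small halogen such as fluoro. No supporting measurement is available to explain why the acetyl compound behaves this way.

This exchange alters both the group and where it sits on the ring, so the compounds shown cannot separate the contribution of the acetyl group from that of its placement. From the compounds shown here alone, whether an amine or a carboxylic acid would serve equally well there also remains open.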